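This account rests on a few compounds, and the source may have more. Where it says the series, first, only, none or still open, it means among the compounds named here.

Measured in an ADME assay on S9 fraction from liver (Rattus norvegicus) for metabolic stability, with a stated time of 1 h; a higher number here means that more of the compound is left, a lower number that less of the compound is left:
Compound 1 `N#Cc1cnc(NCc2cnccc2C(F)(F)F)cc1NC[C@H]1C[C@@H](O)C1`: 44%
Compound 2 `N#Cc1cnc(NCc2cnccc2C(F)(F)F)cc1NC[C@H]1CC[C@@H](O)CC1`: 18%

Compound 2 holds the lower of the two numbers, at 18% in this assay. Compound 3 `N#Cc1cnc(NCc2cnccc2C(F)(F)F)cc1NCCC1CCOCC1` differs from it as follows: (oxan-4-yl)methyl in place of 4-hydroxycyclohexyl on a saturated chain carbon bound to a nitrogen on an aromatic ring. Here (oxan-4-yl)methyl stands in place of 4-hydroxycyclohexyl. Within the data shown here, the only measured step nearby is a number 26 percentage points lower from compound 1 to compound 2 (beyond the scatter), a modest one beyond the scatter, with 4-hydroxycyclohexyl in place of 3-hydroxycyclobutyl. It does not test this swap, so it gives no direction and only a rough idea of size. The expected step is a number 2 percentage points higher from compound 2 to compound 3 (within the scatter), with no change beyond the scatter anticipated. For compound 3 the estimate is 20%, ranging from 6% to 42%.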

Compound 3, percent of the compound remaining: 0%
Compound 3: middle estimate off by 20 percentage points, on the high side; measured number below the stated range.
By their numbers in this assay, from the lowest: compound 3; then compound 2; then compound 1.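

In this assay, (oxan-4-yl)methyl in place of 4-hydroxycyclohexyl gives a number 18 percentage points lower from compound 2 to compound 3 (beyond the scatter) and, set against 3-hydroxycyclobutyl, gives a number 44 percentage points lower from compound 1 to compound 3 (beyond the scatter) as the larger step. Since compound 2 and compound 3 have the same atoms joined differently, this position responds to how those atoms are arranged, not to their number alone. Nothing available explains these steps. The compounds shown leave open whether the loss follows from the missing hydroxyl or from the oxygen sitting in the ring, and how a 4-aminocyclohexyl group would fare in this assay at this position.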